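Series notes: para-halogen and ortho-chloro anilides

The source may report more compounds than this note shows. Statements on the series, on what has been measured and on what is new or still open speak of the compounds shown alone.

Measured so far:
compound 1, `O=C(CSC(=S)N[C@H]1CCOC1=O)Nc1ccc(Cl)cc1`, 50300 nM
compound 2, `O=C(CSC(=S)N[C@H]1CCOC1=O)Nc1ccc(Br)cc1`, 66500 nM
compound 3, `O=C(CSC(=S)N[C@H]1CCOC1=O)Nc1ccccc1Cl`, 90800 nM

All three share one core and differ only in the aryl group on the amide-type nitrogen. In a functional assay on MCF7 cells (Homo sapiens) for cytotoxicity, read by MTT assay, with a stated time of 72 h (a higher number here means a weaker inhibitor, a lower number a stronger inhibitor), compound 3 has the top number of the three, but its gaps to the others, a 1.8-fold higher number from compound 1 to compound 3 (0.26 log units; within the scatter) and a 1.4-fold higher number from compound 2 to compound 3 (0.14 log units; within the scatter), both lie within the scatter, so the three cannot be told apart.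

Compound 4, `O=C(CSC(=S)N[C@H]1CCOC1=O)Nc1ccc(F)cc1`, is not yet measured. It differs from compound 3 by 4-fluorophenyl in place of 2-chlorophenyl on an amide-type nitrogen. Among the measured compounds shown here, two measured steps bear on this. The move of the chloro from the 4-position to the 2-position, a 1.8-fold higher number from compound 1 to compound 3 (0.26 log units; within the scatter), stayed within the scatter; the exchange of one halogen for another at the same place, a 1.3-fold higher number from compound 1 to compound 2 (0.12 log units; within the scatter), also stayed within the scatter. The change to compound 4 combines a move back to the 4-position with a halogen exchange, so no step beyond the scatter is expected in this assay, in either direction.

On that basis compound 4 is estimated at 60000 nM, with a range of 25000 nM to 140000 nM, which amounts to an expected step of a 1.5-fold lower number from compound 3 to compound 4 (0.18 log units; within the scatter).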

Compound 4, half-maximal inhibitory concentration: 5830 nM
The estimate for compound 4 lay 10-fold (1.01 log units) above the measured number; measured number below the stated range.
By their numbers in this assay, from the lowest: compound 4; then compounds 1, 2 and 3 (each within the scatter of the next).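

In this assay the halogens on this ring are not interchangeable: an 11-fold lower number from compound 2 to compound 4 (1.06 log units; beyond the scatter) and an 8.6-fold lower number from compound 1 to compound 4 (0.94 log units; beyond the scatter) both lie beyond the scatter, whereas a 1.3-fold higher number from compound 1 to compound 2 (0.12 log units; within the scatter) does not. Compound 4 is thus the strongest of the four, and its fluoro sets it apart from both the chloro and the bromo compound. Set against the 2-chlorophenyl on the amide-type nitrogen, the 4-fluorophenyl gives a 16-fold lower number from compound 3 to compound 4 (1.19 log units; beyond the scatter) and so also stands clear of compound 3.

No measurement at hand bears on why fluoro behaves differently here.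

As far as these compounds go, the finding rests on compound 4 alone, so it remains open whether the gain belongs to fluoro as such or to the 4-fluorophenyl specifically. A 2-fluorophenyl, an unsubstituted phenyl, or a phenyl carrying a methoxy or an amine would test this.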